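Trimming the amide arm of a pyrazole EP1 ligand

The source may report more compounds than this note shows. Statements on the series, on what has been measured and on what is new or still open speak of the compounds shown alone.

The measured compounds and their numbers in an assay on CHO-K1 cells for displacement of a labelled ligand from prostaglandin E2 receptor EP1 subtype (Homo sapiens) (on this read-out lower numbers stand for stronger inhibition and higher numbers for weaker inhibition), are:
compound 1 `Cc1cc(C(=O)Nc2cccc(F)c2)nn1Cc1cc(Cl)ccc1OCc1ccccc1`, giving 200 nM;
compound 2 `Cc1cc(C(N)=O)nn1Cc1cc(Cl)ccc1OCC(C)C`, giving 126 nM;
compound 3 `Cc1cc(C(=O)NN2CCCCC2)nn1Cc1cc(Cl)ccc1OCC(C)C`, giving 200 nM.

Compound 1 stands level with compound 3 at the digits shown, the two of them together the highest numbers of the three, and compound 2 lies only slightly lower, within the scatter of both. Among the compounds with values here, the single measured step, a 1.6-fold higher number from compound 2 to compound 3 (0.20 log units; within the scatter), shows that adding a ring to the amide-type nitrogen of the shared core leaves the number essentially unchanged.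

Compound 4 `CC(=O)Nc1cc(C)n(Cc2cc(Cl)ccc2OCc2ccccc2)n1` differs from compound 1 in one place: acetamido in place of (3-fluorophenyl)carbamoyl on an aromatic carbon. This is a reversed and much smaller amide at the same aromatic carbon, a change the measured step only touches at a distance, since that step alters what sits on the amide-type nitrogen, not the orientation or size of the whole group. Compound 2 nevertheless shows that a small amide at this position, with a different ether chain, still gives a number in the same range as compound 1. The expectation is therefore a step of about a 1.3-fold higher number from compound 1 to compound 4 (0.10 log units; within the scatter), possibly a modest weakening but not one confidently beyond the scatter. Compound 4 is thus estimated at 250 nM, with a range from 80 nM to 800 nM.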

Compound 4, half-maximal inhibitory concentration: 316 nM
Beside the measured number, compound 4's estimate is 1.3-fold (0.10 log units) below it, within the range that was stated.
By their numbers in this assay, from the lowest: compounds 2, 1, 3 and 4 (each within the scatter of the next, the first and the last beyond it).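

Exchanging (3-fluorophenyl)carbamoyl for acetamido on this aromatic carbon of the core of compound 1 gives a 1.6-fold higher number from compound 1 to compound 4 (0.20 log units; within the scatter) in this assay, so the numbers of these two compounds cannot be told apart, even though the group shrinks from 10 heavy atoms to 4 and loses its six-membered aromatic ring. The earlier step changed only what sits on the amide-type nitrogen and kept the carbonyl on the ring carbon, whereas this change also turns the amide around, so that its nitrogen now stands on the ring carbon, and the hydrogen-bond donor and acceptor counts of the group stay the same. Nothing shown here accounts for this result or says which part of the group, if any, matters to the number.

The compounds shown leave open whether a carboxylic acid or a plain amine on this aromatic carbon would keep the number in the same range, or whether a longer chain in place of the methyl of the acetamido group would shift it. They also leave open how acetamido at this carbon reads out when paired with the 2-methylpropyl ether chain of compound 2 rather than the benzyl ether of compound 4.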